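A few compounds are considered here, and "the series" means these few. Any claim that something is new, unique, unknown or untested is made for them only; others in the source may bear on it.

Working notes. The series shares the core of compound 1 `CC1=CC[C@H](C(C)(C)NC(=S)NN)CC1`, for which a functional assay on UACC-62 cells (Homo sapiens) for inhibition, read by sulforhodamine B assay, with a stated time of 48 h (a higher number here means a weaker inhibitor of growth, a lower number a stronger inhibitor of growth), records "not determined" (no result reported). Compound 2 `CC1=CC[C@H](C(C)(C)NC(=S)N/N=C/c2ccccc2)CC1` gives 31600 nM in this assay. Compound 3 `CC1=CC[C@H](C(C)(C)NC(=S)N/N=C/c2ccc(O)cc2)CC1` gives only a limit in this assay, > 100000 nM, and thus stands among the entries without a single number. Compound 4 `CC1=CC[C@H](C(C)(C)NC(=S)N/N=C/c2ccc(Cl)cc2)CC1` is the compound still to be measured. Among the compounds with values here, the one measured step that bears on that move is an at least 3.1-fold higher number from compound 2 to compound 3 (0.50 log units; beyond the scatter); it ran up to the limit given in the limit of > 100000 nM in this assay, at which 1 of the 3 values shown sits. The change to compound 4 is chloro in place of hydroxy on an aromatic carbon. Taking away the hydroxy is expected to undo that step, and compound 4 is expected to sit near compound 2 with its 31600 nM, a step of an at least 3.3-fold lower number from compound 3 to compound 4 (0.52 log units; beyond the scatter). The estimate for compound 4 in this assay is 30000 nM, ranging from 8000 nM to 100000 nM.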

Compound 4, concentration for 50% growth inhibition: 11200 nM
Beside the measured number, compound 4's estimate is 2.7-fold (0.43 log units) above it; measured number inside the range.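

In this assay, a substituent at this position, para to a large group, does not only weaken growth inhibition: chloro in place of hydrogen gives a 2.8-fold lower number from compound 2 to compound 4 (0.45 log units; beyond the scatter), so hydroxy and chloro move the number in opposite directions from the unsubstituted phenyl. The change from 4-hydroxyphenyl to 4-chlorophenyl gives an at least 8.9-fold lower number from compound 3 to compound 4 (0.95 log units; beyond the scatter). For compound 3, > 100000 nM is a limit of the assay and not a number, so this step has no upper size.

Where a methoxy, an amine or a carboxylic acid at this position would fall relative to chloro and hydroxy remains open. With only these two substituents, the compounds shown do not tell which feature of the group sets the number.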